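Methyl for Vinyl, Repeated on a Second Core

The source may hold more compounds than are shown below. What is called first, only, known or untested is meant among the compounds shown, and "the series" means these compounds.

Compound 1 `CCc1cc(C(C)=O)c(O)cc1OCCCCC#N`: 92%
Compound 2 `C=CCc1cc(C(C)=O)c(O)cc1OCCCCC#N`: 92%
Compound 3 `C=CCc1cc(C(C)=O)c(O)cc1OCc1cccc(C#N)c1`: 71%

The three measured compounds were tested in an assay on isolated protein for inhibition of leukotriene B4 receptor 1 (Homo sapiens), tested at 10 uM; on this read-out lower numbers stand for less inhibition and higher numbers for more inhibition at the one concentration tested (going by the name of the read-out). Compound 2 and compound 1 share one core and differ only by the change (methyl in place of vinyl on a saturated chain carbon bound to an aromatic carbon); the step of no change at the digits printed from compound 2 to compound 1 (within the scatter) shows this change to be flat on that core. Compound 3 carries a different core, and the difference between the two cores is not broken down here. Compound 3 stands lowest of the three numbers; its nearest neighbour is compound 1, whose value lies beyond the scatter above it, and compound 2 lies equally far above.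

Compound 4 `CCc1cc(C(C)=O)c(O)cc1OCc1cccc(C#N)c1` has not yet been measured. It is made from compound 3 by the change (methyl in place of vinyl on a saturated chain carbon bound to an aromatic carbon), the same change, in the same place, that turns compound 2 into compound 1. Since that earlier step on the first core produced no change, the step from compound 3 to compound 4 is expected to be of the same size, that is no change at the digits printed from compound 3 to compound 4 (within the scatter), in this assay. This expectation rests on a single precedent, and the core of compound 3 is different, so some widening of the range is in order. Compound 4 is therefore estimated at 71%, with the likely span running from 58% to 84%.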

Compound 4, a percentage reported as inhibition, at one concentration (the size of the read-out at that concentration, not a potency): 58%
The estimate for compound 4 lay 13 percentage points above the measured number; the measured number falls inside the stated range.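

On the core of compound 3, methyl in place of vinyl on a saturated chain carbon bound to an aromatic carbon, the same difference as allyl to ethyl, gives a number 13 percentage points lower from compound 3 to compound 4 (beyond the scatter) in this assay. Two pairs on two cores are too few to set a rule for the series: they do not show that the change acts identically on every core, nor that the core decides the size of the step, and they speak only for this one read-out at its one concentration. What they do show is that the change carried from one core to the other without a difference between the two steps that stands clear of the scatter: the same change on two cores in this assay, no change at the digits printed (within the scatter) from compound 2 to compound 1 and a number 13 percentage points lower (beyond the scatter) from compound 3 to compound 4, 13 percentage points apart, within the scatter of two such steps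

The compounds shown leave open how a longer chain such as butyl, or a ring such as cyclopropyl, would read in place of the allyl or ethyl group on either core. They also leave open whether the same step would hold if the nitrile gave way to a carboxylic acid or an amine, since the nitrile is present in all four compounds.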